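From aryl amide to cyclohexyl amide: an untested step

A few compounds are considered here, and "the series" means these few. Any claim that something is new, unique, unknown or untested is made for them only; others in the source may bear on it.

Measured compounds:
compound 1 `CCN(CC)c1ccc(NC(=O)c2c(-c3c(Cl)cccc3Cl)noc2CCOC)cc1`, 110 nM
compound 2 `CCN(CC)c1ccc(NC(=O)c2c(-c3c(Cl)cccc3Cl)noc2CCC2OCCCO2)cc1`, 6 nM
compound 3 `CCN(CC)c1ccc(NC(=O)c2c(-c3c(Cl)cccc3Cl)noc2CN2CCCC2=O)cc1`, 122 nM

In an in vitro assay on CHO-K cells with growth hormone secretagogue receptor type 1 (Homo sapiens) as the target (a lower number here means a stronger inhibitor, a higher number a weaker inhibitor), compound 2 gives the lowest number of the three: an 18-fold lower number from compound 1 to compound 2 (1.26 log units; beyond the scatter), and a 20-fold higher number from compound 2 to compound 3 (1.31 log units; beyond the scatter). The remaining pair differs only within the scatter, a 1.1-fold higher number from compound 1 to compound 3 (0.04 log units; within the scatter). All three steps change the chain on the shared core; none of them touches the amide side.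

Compound 4 `CCN(CC)[C@H]1CC[C@H](NC(=O)c2c(-c3c(Cl)cccc3Cl)noc2CCC2OCCCO2)CC1` is unmeasured. It differs from compound 2 by 4-(diethylamino)cyclohexyl in place of 4-(diethylamino)phenyl on an amide-type nitrogen. For the measured compounds named here, no measured step bears on this change, so the three steps above give no guide to its size or direction. The expectation therefore rests on compound 2 alone, with a wide range and no firm direction: compound 4 is estimated at 15 nM (range 3 nM to 80 nM), which would be a 2.5-fold higher number from compound 2 to compound 4 (0.40 log units; beyond the scatter), a step that may fall within or beyond the scatter.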

Compound 4, half-maximal inhibitory concentration: 87 nM
For compound 4 the middle estimate is 5.8-fold (0.76 log units) below the measured one; the measured number lies above the stated range.
By their numbers in this assay, from the lowest: compound 2; then compounds 4, 1 and 3 (each within the scatter of the next).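

In this assay, for the compounds shown here, the earlier steps all changed the chain on the shared core, and this is the first measured change on the amide side: with the chain of compound 2 held fixed, 4-(diethylamino)cyclohexyl in place of 4-(diethylamino)phenyl gives a 15-fold higher number from compound 2 to compound 4 (1.16 log units; beyond the scatter) as a large step. The two groups have matching counts of heavy atoms, hydrogen-bond donors and hydrogen-bond acceptors; they differ in a non-aromatic ring replacing an aromatic one and in the two defined stereocentres, so the amide side responds strongly to a change that leaves those counts untouched. Nothing shown accounts for the size of this step.

The compounds shown leave open whether the ring's aromatic character or the stereochemistry of the cyclohexyl ring matters more, and whether a pyridine or piperidine ring would behave like either group here. They also leave open whether the step would be similar with the chains of compound 1 or compound 3.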